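Swapping the amide ring of a thyroid receptor blocker

The compounds below may be only part of what the source reports. "The series", "measured", "known", "first", "only" and "open" are said of these compounds alone.

Compound 1 `COc1cc(C(=O)N2CCC(O)C(C)C2)cc2nc(NCc3cc(Cl)ccn3)oc12`: 190 nM in an assay on isolated protein for inhibition of thyroid hormone receptor beta (Homo sapiens), read by fluorescence, with a stated time of 30 min; on this read-out higher numbers stand for weaker inhibition and lower numbers for stronger inhibition
Compound 2 `COc1cc(C(=O)N2CCC(O)C(C)C2)cc2nc(NCc3cc(Cl)ccc3O)oc12`: 170 nM
Compound 3 `COc1cc(C(=O)N2CCC(O)C(C)C2)cc2nc(N[C@H](C)c3cccc(Cl)c3)oc12`: 48 nM

Compound 3 stands lowest of the three, and since both a 4.0-fold lower number from compound 1 to compound 3 (0.60 log units; beyond the scatter) and a 3.5-fold lower number from compound 2 to compound 3 (0.55 log units; beyond the scatter) lie beyond the scatter, it is the strongest inhibitor measured here. Compound 4 `COc1cc(C(=O)N2C[C@H](C)OC[C@@H]2CCO)cc2nc(N[C@H](C)c3cccc(Cl)c3)oc12` keeps everything in compound 3 except the ring on the carbonyl carbon: 5-(2-hydroxyethyl)-2-methylmorpholin-4-yl in place of 4-hydroxy-3-methylpiperidin-1-yl on a carbonyl carbon. Among the compounds with values here, none of the measured steps touches this part of the molecule; each of them, a 1.1-fold lower number from compound 1 to compound 2 (0.05 log units; within the scatter) included, changes only the group on the nitrogen on the aromatic ring. The data therefore give no guide to the direction of this change, and the expectation is a step within the scatter, a 1.3-fold higher number from compound 3 to compound 4 (0.10 log units; within the scatter). Compound 4 is estimated at 60 nM in this assay, between 20 nM and 200 nM.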

Compound 4, half-maximal inhibitory concentration: 4 nM
For compound 4 the middle estimate is 15-fold (1.18 log units) above the measured one; the whole stated range lies above it.
By their numbers in this assay, from the lowest: compound 4; then compound 3; then compounds 2 and 1 (each within the scatter of the next).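

In this assay, 5-(2-hydroxyethyl)-2-methylmorpholin-4-yl in place of 4-hydroxy-3-methylpiperidin-1-yl on a carbonyl carbon gives a 12-fold lower number from compound 3 to compound 4 (1.08 log units; beyond the scatter), larger than any earlier step, all of which changed the group on the nitrogen on the aromatic ring. Within the data shown here, this part of the molecule, untouched by the earlier compounds, can therefore move the number strongly. Nothing measured here says why the step is so large.

On these data alone, the new ring brings a second ring oxygen, a hydroxyethyl chain and defined stereocentres all at once, so which of these carries the step stays open. Also open, as far as these compounds go, is whether an amine in place of the hydroxyl on that chain would keep the number this low.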